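The compounds below may be only part of what the source reports. "The series", "measured", "known", "first", "only" and "open" are said of these compounds alone.

In a functional assay (on this read-out lower numbers stand for stronger inhibition and higher numbers for weaker inhibition), compound 1 (`CC(C)=CCOc1ccc2c(c1)OC(c1ccccc1)CC2=O`) gives 6070 nM, compound 2 (`CC(C)=CCOc1ccc2c(c1)OC(c1ccc(C)cc1C)CC2=O`) gives 8260 nM, and compound 3 (`CC(C)=CCOc1cc(O)c2c(c1)OC(c1ccccc1)CC2=O`) gives 7320 nM. Compound 3 has no real separation from the other two, as its gaps to compound 1 and compound 2 both lie within the scatter. Compound 4 (`CC(C)=CCOc1cc(O)c2c(c1)OC(c1cccc(Cl)c1)CC2=O`) has not yet been measured. It differs from compound 3 by chloro in place of hydrogen on an aromatic carbon, so that phenyl becomes 3-chlorophenyl: chloro in place of hydrogen on an aromatic carbon. The closest measured precedent is a 1.4-fold higher number from compound 1 to compound 2 (0.13 log units; within the scatter), where 2,4-dimethylphenyl stands in place of phenyl, a change to the same group. The other step, a 1.2-fold higher number from compound 1 to compound 3 (0.08 log units; within the scatter), with hydroxy in place of hydrogen on an aromatic carbon, shows that compound 3 keeps a number close to that of its parent, but it concerns a different place. Among the compounds with values here, neither step goes beyond the scatter, and no measured compound carries a chloro group, so the data offer no direction for this change. In this assay the expected result is therefore no step beyond the scatter. The estimated step is a 1.0-fold lower number from compound 3 to compound 4 (0.02 log units; within the scatter). For compound 4 the estimate is 7000 nM, with an expected range from 3500 nM to 14000 nM.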

Compound 4, half-maximal inhibitory concentration: 6060 nM
Compound 4: the middle estimate sits 1.2-fold (0.06 log units) above what was measured; the measured number falls inside the stated range.
By their numbers in this assay, from the lowest: compounds 4, 1, 3 and 2 (each within the scatter of the next).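

In this assay the chloro group gives a 1.2-fold lower number from compound 3 to compound 4 (0.08 log units; within the scatter), so placing this first halogen on the phenyl ring, meta to a large group, yields no separation from the parent. Read with a 1.4-fold higher number from compound 1 to compound 2 (0.13 log units; within the scatter), this gives two replacements on that ring, one in the series with the hydroxy group and one in the series without it, and neither step leaves the scatter; across these compounds, the ring accepts added chloro or methyl groups without a readable shift in either direction. No measurement is available that could explain this flat result.

The compounds shown leave open whether any group on this ring can move the number beyond the scatter, since an amine or a carboxylic acid in place of the chloro group would test a very different kind of substituent from those present here. On these data alone, it also remains open whether chloro would give a similar result on another carbon of the ring, or on the core of compound 1, which lacks the hydroxy group.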